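Swapping Methyl for Trifluoromethyl on the Piperidine Ring

A few compounds are considered here, and "the series" means these few. Any claim that something is new, unique, unknown or untested is made for them only; others in the source may bear on it.

Compound 1 `CCCCN(C)c1cc(C(F)(F)F)ccc1CNC(=O)C(C)c1ccc(NS(C)(=O)=O)c(F)c1`: in an assay on CHO cells for antagonist activity at transient receptor potential cation channel subfamily V member 1 (Homo sapiens), read by FLIPR (on this read-out lower numbers stand for stronger inhibition and higher numbers for weaker inhibition), compound 1 gives 1.2 nM.
Compound 2 `CC1CCN(c2cc(C(F)(F)F)ccc2CNC(=O)C(C)c2ccc(NS(C)(=O)=O)c(F)c2)CC1`: in this assay compound 2 gives 0.9 nM.

Within the data shown here, only two compounds have been measured, and their values sit within the usual scatter of each other, so neither can be called more potent than the other. Among the measured compounds shown here, the single measured step, a 1.3-fold lower number from compound 1 to compound 2 (0.12 log units; within the scatter), replaces the amine group on the aromatic ring and does not reach beyond the scatter.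

Compound 3 `CC(C(=O)NCc1ccc(C(F)(F)F)cc1N1CCC(C(F)(F)F)CC1)c1ccc(NS(C)(=O)=O)c(F)c1` has not yet been measured. It departs from compound 2 by trifluoromethyl in place of methyl on a saturated ring carbon. For the measured compounds named here, no measured step touches this position: the one known step concerns a different part of the molecule and was itself within scatter. With no guide pointing in either direction, the expectation is that compound 3 stays close to compound 2, a 1.1-fold higher number from compound 2 to compound 3 (0.05 log units; within the scatter). For compound 3 the estimate in this assay is 1 nM, with a range from 0.4 nM to 3 nM.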

Compound 3, inhibition constant: 0.4 nM
The estimate for compound 3 lay 2.5-fold (0.40 log units) above the measured number; low and high end bracket the measured number.
By their numbers in this assay, from the lowest: compound 3; then compounds 2 and 1 (each within the scatter of the next).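

In this assay, the saturated ring carbon three ring bonds from the ring nitrogen proves sensitive to what it carries: trifluoromethyl in place of methyl gives a 2.3-fold lower number from compound 2 to compound 3 (0.35 log units; beyond the scatter), a modest step, but the first in this series to pass beyond the scatter. Replacing butyl(methyl)amino on the aromatic carbon with 4-(trifluoromethyl)piperidin-1-yl gives a 3.0-fold lower number from compound 1 to compound 3 (0.48 log units; beyond the scatter), whereas 4-methylpiperidin-1-yl in that same place gave no step beyond the scatter. Nothing available explains why the trifluoromethyl group goes with the lower number.

On these data alone, how other groups on this ring carbon would read remains open, for example a hydroxyl, a nitrile or an ethyl chain. As far as these compounds go, it is also open whether the same swap of methyl for trifluoromethyl would give a similar step if the rest of the molecule were changed.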